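The source may report more compounds than this note shows. Statements on the series, on what has been measured and on what is new or still open speak of the compounds shown alone.

Compound 1 `Cc1cccc(-c2cc(Cl)cc(Cl)c2/C=C/[C@@H]2C[C@@H](O)CC(=O)O2)c1` is measured in an assay for inhibition of 3-hydroxy-3-methylglutaryl-coenzyme A reductase (Rattus norvegicus) (a lower number here means a stronger inhibitor, a higher number a weaker inhibitor), where compound 1 gives 16 nM. Among the three numbers available, compound 1 stands second highest. Its closest neighbour is compound 3 `Cc1cc(C)c(/C=C/[C@@H]2C[C@@H](O)CC(=O)O2)c(-c2ccc(F)cc2)c1`, which in this assay gives 13 nM, a gap that lies within the usual scatter of repeated measurements, so the two numbers cannot be told apart. The far end is compound 2 `O=C1C[C@H](O)CC(CCc2ccccc2-c2ccccc2)O1`, which in this assay gives 44000 nM, a number far beyond the scatter and showing a much weaker inhibitor.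

Compound 4 `COc1cccc(-c2cc(Cl)cc(Cl)c2/C=C/[C@@H]2C[C@@H](O)CC(=O)O2)c1` is not yet measured. It differs from compound 1 in one place: methoxy in place of methyl on an aromatic carbon. Going by the values given here, no comparable pair of measured compounds exists here, so nothing shows how such a swap moves the number. The expectation is therefore a small step, in no particular direction and not beyond the scatter, namely no change at the digits printed from compound 1 to compound 4 (within the scatter). For compound 4 the estimated value in this assay is 16 nM, with a likely range from 6 nM to 45 nM.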

Compound 4, half-maximal inhibitory concentration: 50 nM
Beside the measured number, compound 4's estimate is 3.1-fold (0.49 log units) below it; measured number outside the range, above it.
By their numbers in this assay, from the lowest: compounds 3 and 1 (each within the scatter of the next); then compound 4; then compound 2.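

Changing 3-methylphenyl to 3-methoxyphenyl gives a 3.1-fold higher number from compound 1 to compound 4 (0.49 log units; beyond the scatter) in this assay. Going by these compounds alone, this is the first pair here that differs in one place, and it shows that the number responds to a change on this aromatic carbon: the swap adds an oxygen and a hydrogen-bond acceptor, and the step, though modest, lies beyond the scatter. The data offer no measurement that explains the rise.

A single pair cannot show whether the oxygen itself matters or simply the larger group, and an ethyl, a hydroxyl or a chlorine at the same place would help to separate those readings. It also leaves open whether the same swap would move the number similarly on another core.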